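A Carbon-Only Ring Replaces 5-Hydroxypyridin-2-yl

This account rests on a few compounds, and the source may have more. Where it says the series, first, only, none or still open, it means among the compounds named here.

Among the measured compounds shown here, in a physicochemical assay for solubility, measured as kinetic solubility (on this read-out higher numbers stand for higher solubility and lower numbers for lower solubility), compound 1 `CCC/N=C1\S/C(=C\c2ccc(O)cn2)C(=O)N1c1ccccc1C` gives 110000 nM and stands highest of the two numbers so far. Compound 2 `Cc1ccccc1N1C(=O)/C(=C/c2ccc(O)c(Cl)c2)S/C1=N\CCCF` gives 20000 nM which is lower by more than the scatter. For the measured compounds named here, compound 3 `CCC/N=C1\S/C(=C\c2ccc(O)c(C)c2)C(=O)N1c1ccccc1C` is still unmeasured and differs from compound 1 in carrying 4-hydroxy-3-methylphenyl in place of 5-hydroxypyridin-2-yl on a double-bonded chain carbon bound to a double-bonded ring carbon as its one change. Compound 2 at 20000 nM also bears a carbon-only ring there, but its chain differs too, so it is a loose guide. A fall beyond the scatter is expected in this assay with a 4.4-fold lower number from compound 1 to compound 3 (0.64 log units; beyond the scatter) as the estimated step. Compound 3 is estimated at 25000 nM with an expected range from 8000 nM to 70000 nM for the measurement.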

Compound 3, solubility: 78000 nM
Compound 3: middle estimate off by 3.1-fold (0.49 log units), on the low side; measured number outside the range, above it.
By their numbers in this assay, from the lowest: compound 2; then compounds 3 and 1 (each within the scatter of the next).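

Among the compounds shown here, this is the first pair that differs in only one place, and it shows that a carbon-only ring can stand on a double-bonded chain carbon bound to a double-bonded ring carbon with no change beyond the scatter: this assay gives a 1.4-fold lower number from compound 1 to compound 3 (0.15 log units; within the scatter). Nothing available explains this result.

Going by these compounds, the step swaps the ring nitrogen and adds the methyl together, so their separate contributions remain unknown. Also open, on these data alone, is how a ring carrying an amine or a carboxylic acid would read at this position.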